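Swapping the Thiophene for Fluorophenyl on the Pyrazoline

A few compounds are considered here, and "the series" means these few. Any claim that something is new, unique, unknown or untested is made for them only; others in the source may bear on it.

Measured compounds:
- compound 1 `NS(=O)(=O)c1ccc2nc(N3N=C(c4ccc(Br)cc4)CC3c3ccc(F)cc3)sc2c1`: 14%
- compound 2 `Cc1ccc(C2CC(c3ccc(Cl)cc3)=NN2c2nc3ccc(S(N)(=O)=O)cc3s2)cc1`: 14%
- compound 3 `NS(=O)(=O)c1ccc2nc(N3N=C(c4ccc(Cl)cc4)CC3c3cccs3)sc2c1`: 14%

The three compounds share one core and differ only in the aryl groups on the five-membered non-aromatic ring. In a functional assay on the whole organism (strain Wistar) for inhibition, with Rattus norvegicus as the target, read by paw edema, with stated times of 1 h and 5 h, at a dose of 20 mg/kg by the oral route (on this read-out higher numbers stand for more inhibition at the one dose given (going by the name of the read-out) and lower numbers for less inhibition), compound 1 gives 14%, compound 2 gives 14% and compound 3 gives 14%. Compound 3 therefore stands level with compound 1 and with compound 2 in this assay; none of the three can be called stronger or weaker than another.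

Among the measured compounds shown here, the one measured step that alters the same place, from compound 2 to compound 3, is no change at the digits printed from compound 2 to compound 3 (within the scatter). It shows that exchanging one aryl group for another on the saturated ring carbon left the read-out unmoved within the scatter.

Compound 4 `NS(=O)(=O)c1ccc2nc(N3N=C(c4ccc(Cl)cc4)CC3c3ccc(F)cc3)sc2c1` is not yet measured. It differs from compound 3 as follows: 4-fluorophenyl in place of thiophen-2-yl on a saturated ring carbon. For the measured compounds named here, compound 4 also carries the same 4-fluorophenyl group as compound 1, which gives 14%; compound 4 carries 4-chlorophenyl where compound 1 carries 4-bromophenyl, and no step is known for that pair.

Because the step from compound 2 to compound 3 is no change at the digits printed from compound 2 to compound 3 (within the scatter), and the measured values sit together, the step from compound 3 to compound 4 is expected to be no change at the digits printed from compound 3 to compound 4 (within the scatter), no change beyond the scatter. Compound 4 is therefore estimated at 14% in this assay, within a range from 4% to 26%.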

Compound 4, a percentage reported as inhibition, in the whole organism at one dose (the size of the read-out at that dose, not a potency): 14%
Estimate against measurement, compound 4: no gap at the digits printed; measured number inside the range.
By their numbers in this assay, from the lowest: compounds 1, 2, 3 and 4 (each within the scatter of the next).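

With compound 4 in hand, this assay shows a second exchange on the saturated ring carbon, 4-fluorophenyl in place of thiophen-2-yl, giving no change at the digits printed from compound 3 to compound 4 (within the scatter), and the position now holds three different aromatic groups at one level. Fluoro in place of methyl on an aromatic carbon of the group at this same position adds no change at the digits printed from compound 2 to compound 4 (within the scatter), so a change of the substituent on that phenyl ring also leaves the read-out where it was. Among the compounds shown here, the new compound also gives the first single-place step at the other aryl group, since chloro in place of bromo on an aromatic carbon gives no change at the digits printed from compound 1 to compound 4 (within the scatter), which extends the flat picture beyond the saturated ring carbon. The data shown offer no explanation for this uniform level.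

From the compounds shown here alone, all of the groups compared at the saturated ring carbon are aromatic rings, so it remains open whether an amine, a carboxylic acid or a longer alkyl chain there would shift the read-out. Going by these compounds, the sulfonamide on the shared core is the same throughout, so what replacing it with a carboxylic acid or a methyl ester would do also remains unknown.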